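The source may report more compounds than this note shows. Statements on the series, on what has been measured and on what is new or still open speak of the compounds shown alone.

Measured so far:

compound 1 `CCCCOC(=O)Nc1cc2nc(C3CCCCC3)[nH]c2cc1N(CC)CCN(C)C`: > 100 ug/mL
compound 2 `CN(C)c1cc2[nH]c(C3CCCCC3)nc2cc1NC(=O)c1ccco1`: > 100 ug/mL
compound 3 `CCN(CC)c1cc2[nH]c(C3CCCCC3)nc2cc1NC(=O)c1cnccn1`: > 100 ug/mL

All three readings in an ADME assay on Vero cells (Chlorocebus sabaeus) for cytotoxicity, read by resazurin assay, with a stated time of 3 days (on this read-out lower numbers stand for stronger inhibition and higher numbers for weaker inhibition), are limits of the assay, not numbers. Compound 2 therefore has no measured value of its own; it stands at the limit of > 100 ug/mL in this assay, at which 3 of the 3 values shown sit, and nothing within the set separates it from compound 1 or compound 3.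

Compound 4 `CCCCCC(=O)Nc1cc2nc(C3CCCCC3)[nH]c2cc1N(C)C` is the next member awaiting measurement in this assay. Against compound 2 the single change is pentyl in place of furan-2-yl on a carbonyl carbon. For the measured compounds named here, no step between measured compounds exists here, so the size of the step cannot be taken from the set; the expectation for the step from compound 2 to compound 4 is a number no higher from compound 2 to compound 4 (the limit leaves the size open), that is, nothing beyond the scatter, with compound 4 most likely again reported only as a limit. Compound 4 is estimated at 100 ug/mL, within a range of 50 ug/mL to 200 ug/mL.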

Compound 4, half-maximal inhibitory concentration: > 100 ug/mL
Compound 4 ended at the assay's limit; the forecaster's own chance of this, stated with the estimate: 80%; the middle value sits exactly at the limit.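

For the compounds shown here, compound 2 and compound 4 both stand only as limits of the assay, so no step between them can be read for pentyl in place of furan-2-yl. The compounds shown leave open whether any of them differs from another: the limit of > 100 ug/mL in this assay, at which 4 of the 4 values shown sit.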